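Heptyl to ethyl, starting from a missing number

The source may report more compounds than this note shows. Statements on the series, on what has been measured and on what is new or still open speak of the compounds shown alone.

- Compound 1 `CCC(CC)O[C@@H]1C=C(C(=O)OCCCOC(=O)c2ccc3ccccc3c2O)C[C@H](NC(=N)N)[C@H]1NC(C)=O` gives 0.82
- Compound 2 `CC(=O)N[C@H]1[C@H]([C@H](O)[C@H](O)CO)OC(C(=O)OCCCOC(=O)c2ccc3ccccc3c2O)=C[C@@H]1NC(=N)N` gives 0.75
- Compound 3 `CCCCCCCOC(=O)C1=C[C@H](NC(=N)N)[C@@H](NC(C)=O)[C@H]([C@H](O)[C@H](O)CO)O1` gives "not determined" (no result reported)
- Compound 4 `CCOC(=O)C1=C[C@H](NC(=N)N)[C@@H](NC(C)=O)[C@H]([C@H](O)[C@H](O)CO)O1` is still unmeasured

All of these results come from a physicochemical assay for lipophilicity, measured as octanol-water partition, at pH 7.4, tested at 100 ug/mL (on this read-out higher numbers stand for higher lipophilicity and lower numbers for lower lipophilicity), and they leave compound 3 without a place on the scale. No result was reported for it, so it cannot be ranked against the others and offers no number to start from. Compound 1 and compound 2 lie within the usual scatter of each other, so they give one general level rather than an order.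

The structural change is simple: hydrogen in place of pentyl on a saturated chain carbon, two bonds along the chain from an oxygen next to a carbonyl group. This is hydrogen in place of pentyl on a saturated chain carbon, two bonds along the chain from an oxygen next to a carbonyl group. Cut one bond further out, the same difference reads heptyl to ethyl.

Among the measured compounds shown here, no measured pair in this set shows what such a change does, so any forecast is uncertain. A clear step toward lower numbers is expected, well beyond the scatter, but its size cannot be anchored to compound 3. In this assay compound 4 is estimated at -1 with an expected range from -2 to 0 on this scale.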

Compound 4, distribution coefficient: -0.28
Compound 4: the middle estimate sits 0.72 log units below what was measured, and the stated range covers the measured number.
By their numbers in this assay, from the lowest: compound 4; then compounds 2 and 1 (each within the scatter of the next).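

In this assay compound 4 gives -0.28, but compound 3 has no number to set against it, so no step can be read between compound 3 and compound 4. No other information at hand bears on this result. The compounds shown leave open how far going from heptyl to ethyl shifts the read-out.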